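The source may report more compounds than this note shows. Statements on the series, on what has been measured and on what is new or still open speak of the compounds shown alone.

Values in an in vitro ADME assay on microsomes from Gut (Homo sapiens) for metabolic stability, in the presence of a further agent that is not named here (on this read-out lower numbers stand for slow clearance and higher numbers for fast clearance), so far

Compound 1 `CC(C)(CO)CNC(=O)c1cc2cc(C#N)ccc2n1Cc1cccc(OC(F)(F)F)c1` gives 136 mL.min-1.g-1
Compound 2 `COc1ccc(Cl)cc1Cn1c(C(=O)NCC(C)(C)CO)cc2cc(C#N)ccc21` gives 63 mL.min-1.g-1

Compound 2 at 63 mL.min-1.g-1 holds the lower of the two numbers, and compound 1 at 136 mL.min-1.g-1 stands higher by more than the usual scatter. For the measured compounds named here, no measured pair differs in one place only, so no direct step is available as a guide.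

Compound 3 `Cc1ccc(C)c(Cn2c(C(=O)NCC(C)(C)CO)cc3cc(C#N)ccc32)c1` is not yet measured. Its change from compound 2 is 2,5-dimethylphenyl in place of 5-chloro-2-methoxyphenyl on a saturated chain carbon bound to an aromatic nitrogen and reads in words as 2,5-dimethylphenyl in place of 5-chloro-2-methoxyphenyl on a saturated chain carbon bound to an aromatic nitrogen. The two measured compounds mark the only range known in this assay for this series, and compound 3 is expected to land inside that range, somewhat above compound 2. The expected move is a 1.5-fold higher number from compound 2 to compound 3 (0.18 log units; within the scatter) as an upward step that may not clear the scatter. For compound 3 the estimated value is 95 mL.min-1.g-1 with an expected range from 50 mL.min-1.g-1 to 180 mL.min-1.g-1 until a measurement is available.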

Compound 3, intrinsic clearance in microsomes: 124 mL.min-1.g-1
The estimate for compound 3 lay 1.3-fold (0.12 log units) below the measured number, and the stated range covers the measured number.
By their numbers in this assay, from the lowest: compounds 2, 3 and 1 (each within the scatter of the next, the first and the last beyond it).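

For the compounds shown here, the step in this assay is a 2.0-fold higher number from compound 2 to compound 3 (0.29 log units; within the scatter), the first reading of a single change on a saturated chain carbon bound to an aromatic nitrogen, with the rest of the molecule held constant. Exchanging 5-chloro-2-methoxyphenyl for 2,5-dimethylphenyl removes the chlorine, the oxygen and the one hydrogen-bond acceptor of the group, yet the two compounds cannot be told apart on this read-out, so this exchange gives no resolved effect on clearance at this position. No supporting measurement bears on this result, and the data offer no explanation for it.

The exchange alters two substituents at once, so the separate contributions of chloro to methyl and of methoxy to methyl remain unresolved, and 5-chloro-2-methylphenyl would be the intermediate that splits them. Also open, going by these compounds, is whether a more different group at this position, such as a pyridine ring in place of the phenyl or a phenyl ring carrying a carboxylic acid or an amine, would move the number beyond the scatter.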